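This account rests on a few compounds, and the source may have more. Where it says the series, first, only, none or still open, it means among the compounds named here.

Of the compounds shown here, two share one core, and compound 2 `C[C@@H]1CC(c2cnc3c(C#N)nn([C@H](C)c4ccc(Cl)cc4Cl)c3n2)=CC[C@@H]1N1CCC[C@H]1C` carries the lowest of the two numbers so far in a functional assay on cells for antagonist activity at C-C chemokine receptor type 4 (Homo sapiens), read by fluorescence and calcium flux, with stated times of 2.5 s and 45 s (on this read-out higher numbers stand for weaker inhibition and lower numbers for stronger inhibition), giving 34 nM. Compound 1 `C[C@@H]1CC(c2cnc3c(C#N)nn([C@H](C)c4ccc(Cl)cc4Cl)c3n2)=CC[C@@H]1N1CCC[C@H]1CO` gives 40 nM in this assay, and the step of a 1.2-fold lower number from compound 1 to compound 2 (0.07 log units; within the scatter) lies within the scatter. Compound 3 `C[C@@H]1CC(c2cnc3c(C#N)nn([C@H](C)c4ccc(Cl)cc4Cl)c3n2)=CC[C@@H]1N1CCC[C@H]1C(N)=O` alters compound 2 at the same five-membered ring: carbamoyl in place of methyl on a saturated ring carbon. Among the compounds with values here, only one measured step bears on this position, and it was within the scatter; it exchanged hydroxy and hydrogen, whereas the new step introduces a carbamoyl with one hydrogen-bond donor and one hydrogen-bond acceptor, a change that no measured pair mirrors. Compound 3 is therefore expected to land near the present level, with a step of a 1.5-fold higher number from compound 2 to compound 3 (0.17 log units; within the scatter) and a wide margin of uncertainty. The estimate for compound 3 in this assay is 50 nM, within a range from 15 nM to 170 nM.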

Compound 3, half-maximal inhibitory concentration: 54 nM
The estimate for compound 3 lay 1.1-fold (0.03 log units) below the measured number; the measured number falls inside the stated range.
By their numbers in this assay, from the lowest: compounds 2, 1 and 3 (each within the scatter of the next).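

In this assay, carbamoyl in place of methyl on this saturated ring carbon gives a 1.6-fold higher number from compound 2 to compound 3 (0.20 log units; within the scatter), and carbamoyl in place of hydroxymethyl gives a 1.4-fold higher number from compound 1 to compound 3 (0.13 log units; within the scatter). The earlier pair covered only the exchange of hydroxy and hydrogen on the side chain, whereas these steps show that a group with three heavy atoms, one hydrogen-bond donor and one hydrogen-bond acceptor also stays within the scatter of the methyl and hydroxymethyl compounds at this position. No measurement here explains why the three groups read alike.

The compounds shown leave open whether a carboxylic acid, an amine or a longer chain on this ring carbon would also stay at this level. They also leave open whether a substituted amide would do so.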